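The compounds below may be only part of what the source reports. "The series", "measured", "known", "first", "only" and "open" are said of these compounds alone.

Within the data shown here, in a functional assay on HepG2 cells (Homo sapiens) for antiproliferative activity, read by MTT assay, with a stated time of 24 h (on this read-out lower numbers stand for stronger inhibition and higher numbers for weaker inhibition), compound 2 `COc1ccc(C(=O)/C=C/c2cccc([N+](=O)[O-])c2)c2c1C=CC(C)(C)O2` gives 2830 nM, the only true number among the three measured compounds. Compound 1 `COc1ccc(C(=O)/C=C/c2cccc(F)c2)c2c1C=CC(C)(C)O2` reaches only the assay limit of > 10000 nM. Compound 3 `COc1ccc(C(=O)/C=C/c2cccc(C(F)(F)F)c2)c2c1C=CC(C)(C)O2` likewise reaches only the limit of > 10000 nM. Accordingly there is an at least 3.5-fold lower number from compound 1 to compound 2 (0.54 log units; beyond the scatter), and an at least 3.5-fold higher number from compound 2 to compound 3 (0.54 log units; beyond the scatter), while the remaining pair shows a step that the two limits leave unreadable from compound 1 to compound 3. Compound 4 `COc1ccc(C(=O)/C=C/c2ccc(Cl)c(Cl)c2)c2c1C=CC(C)(C)O2` is unmeasured; it differs from compound 2 by 3,4-dichlorophenyl in place of 3-nitrophenyl on a double-bonded chain carbon bound to a double-bonded chain carbon. Both readable steps bear on this change, since compounds carrying fluoro or trifluoromethyl instead of nitro sat at the limit of > 10000 nM in this assay, at which 2 of the 3 values shown sit. A rise beyond the scatter is therefore expected, a 3.2-fold higher number from compound 2 to compound 4 (0.50 log units; beyond the scatter). Compound 4 is estimated at 9000 nM in this assay, within a range from 3000 nM to 30000 nM, with a fair chance of only a limit.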

Compound 4, half-maximal inhibitory concentration: > 10000 nM
Compound 4: only a limit was reported; the forecaster's own chance of this, stated with the estimate: 60%; at least 1.1-fold (0.04 log units) between middle value and limit.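

In this assay, replacing the 3-nitrophenyl group with 3,4-dichlorophenyl gives an at least 3.5-fold higher number from compound 2 to compound 4 (0.54 log units; beyond the scatter). Among these compounds, two chlorines on the ring therefore join fluoro and trifluoromethyl at the limit, leaving compound 2 as the only one with a true number: the limit of > 10000 nM in this assay, at which 3 of the 4 values shown sit. Steps between compounds at this limit cannot be read, so compound 1 and compound 4 cannot be ranked against each other.

The compounds shown leave open whether nitro is unusual at this ring or whether an amine or a carboxylic acid there would also give a true number.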